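A few compounds are considered here, and "the series" means these few. Any claim that something is new, unique, unknown or untested is made for them only; others in the source may bear on it.

Measured in an ADME assay on HepG2 cells (Homo sapiens) for inhibition, read by resazurin assay, with a stated time of 48 h; a higher number here means that more compound is needed for the effect, a lower number that less compound is needed:
- Compound 1 `O=C(Nc1ccc2sc(-c3ccccc3)nc2c1)N1CCCCC1`: > 50 uM
- Compound 2 `O=C(Nc1ccc2sc(-c3ccc(F)c(F)c3)nc2c1)N1CCCC1`: > 50 uM

Compound 2 gives only a limit, > 50 uM, and not a number. It stands at the limit of > 50 uM in this assay, at which 2 of the 2 values shown sit. In compound 3 `O=C(Nc1ccc2sc(-c3ccccc3)nc2c1)N1CCCC1`, phenyl takes the place of 3,4-difluorophenyl on an aromatic carbon: phenyl in place of 3,4-difluorophenyl on an aromatic carbon. Within the data shown here, no measured step shows what this change does. Compound 1 also carries phenyl and likewise gives only a limit, > 50 uM. In this assay, the expected change, a number no higher from compound 2 to compound 3 (the limit leaves the size open), is none beyond the usual scatter. Compound 3 is expected at 50 uM, with an estimated range of 25 uM to 100 uM.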

Compound 3, concentration for 90% of the maximal effect: > 50 uM
Compound 3 ended at the assay's limit (the forecaster's own chance of this, stated with the estimate: 80%); the middle value sits exactly at the limit.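

In this assay, no step can be read among compound 1, compound 2 and compound 3, as all three give only a limit: the limit of > 50 uM in this assay, at which 3 of the 3 values shown sit.

The compounds shown leave open whether phenyl in place of 3,4-difluorophenyl, or pyrrolidin-1-yl in place of piperidin-1-yl, changes the concentration needed at all.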